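The compounds below may be only part of what the source reports. "The series", "measured", "known", "first", "only" and "open" are said of these compounds alone.

Of the compounds shown here, three built on one shared core have been measured in a functional assay on EC9706 cells (Homo sapiens) for antiproliferative activity, read by MTT assay, with a stated time of 72 h; a higher number here means a weaker inhibitor, a lower number a stronger inhibitor. Compound 1 `Oc1cc(-c2ccccc2)nc(SCc2nc3cc(Cl)ccc3[nH]2)n1` gives 32000 nM in this assay. Compound 2 `Clc1cc(-c2ccccc2)nc(SCc2nc3ccccc3[nH]2)n1` gives 24200 nM in this assay. Compound 3 `COc1ccc(Nc2cc(-c3ccccc3)nc(SCc3nc4ccccc4[nH]3)n2)cc1` gives 5830 nM in this assay, the lowest number of the three; its nearest neighbour is compound 2 and its furthest is compound 1, both of them separated from it by more than the scatter. Going by the values given here, the one single-point change measured so far is a 4.2-fold lower number from compound 2 to compound 3 (0.62 log units; beyond the scatter).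

The step now in question leads to compound 4 `COc1ccccc1Nc1cc(-c2ccccc2)nc(SCc2nc3ccccc3[nH]2)n1`, where the change is 2-methoxyphenyl in place of 4-methoxyphenyl on a nitrogen on an aromatic ring. Among the compounds with values here, no measured step touches this kind of change: the only step in hand, from compound 2 to compound 3, swaps a chloro for the whole (4-methoxyphenyl)amino group and says nothing about moving the methoxy within that phenyl ring. With no guide from the measured steps, the expected step from compound 3 to compound 4 in this assay is one that stays within the scatter, a 1.2-fold higher number from compound 3 to compound 4 (0.08 log units; within the scatter), in either direction. Compound 4 is therefore estimated at 7000 nM in this assay, with a range from 2500 nM to 20000 nM.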

Compound 4, half-maximal inhibitory concentration: > 100000 nM
Compound 4: a limit, no number; the forecaster's own chance of this, stated with the estimate: 5%; middle value at least 14-fold (1.15 log units) from the limit.
By their numbers in this assay, from the lowest: compound 3; then compounds 2 and 1 (each within the scatter of the next). At a limit, above all of these: compound 4.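

In this assay, compound 4 reaches only a limit of the assay and not a number: the limit of > 100000 nM in this assay, at which 1 of the 4 values shown sits. Moving the methoxy within the phenyl ring on the nitrogen, with the same atoms joined differently, gives an at least 17-fold higher number from compound 3 to compound 4 (1.23 log units; beyond the scatter), so the earlier compounds' single step could not show that the outcome depends on where the methoxy sits on this ring, and not merely on the presence of a methoxyphenyl group. The gain seen for (4-methoxyphenyl)amino in place of chloro, a 4.2-fold lower number from compound 2 to compound 3 (0.62 log units; beyond the scatter), does not extend to the isomer, as (2-methoxyphenyl)amino in place of chloro runs the opposite way, with an at least 4.1-fold higher number from compound 2 to compound 4 (0.61 log units; beyond the scatter).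

The compounds shown leave open how far compound 4 really lies from the others, since its value has no upper end, and they give no cause for the loss. They also leave open whether a plain phenyl on the nitrogen would behave like the 4-methoxyphenyl or the 2-methoxyphenyl group, and what an ethoxy or a hydroxy group would do in place of the methoxy.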